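One Group Exchanged on the Sulfur of Compound 3

The source may report more compounds than this note shows. Statements on the series, on what has been measured and on what is new or still open speak of the compounds shown alone.

Of the compounds shown here, three with a shared core have been measured in a functional assay on MCF7 cells (Homo sapiens) for inhibition, read by MTT assay, with a stated time of 72 h (a lower number here means a stronger inhibitor, a higher number a weaker inhibitor), so far. Compound 1 (`CN1CCN(c2cc(C(F)(F)F)nc(SCc3ccc(C(F)(F)F)cc3)n2)CC1`) stands at 30200 nM and compound 2 (`FC(F)(F)c1ccc(CSc2nc(Sc3ccccn3)cc(C(F)(F)F)n2)cc1`) at 43200 nM while compound 3 (`FC(F)(F)c1ccc(CSc2nc(Sc3nnnn3-c3ccccc3)cc(C(F)(F)F)n2)cc1`) stands at 39500 nM on the same scale. Compound 3 therefore sits among values that all lie within the scatter of one another, clearly separated from neither of the other two.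

Compound 4 (`FC(F)(F)c1ccc(CSc2nc(SC3=NCCS3)cc(C(F)(F)F)n2)cc1`) departs from compound 3 by a single exchange (a group of 5 heavy atoms (3 carbon, 1 nitrogen, 1 sulfur; one five-membered non-aromatic ring with 2 hetero atoms) in place of a group of 11 heavy atoms (7 carbon, 4 nitrogen; one five-membered aromatic ring with 4 hetero atoms, one six-membered aromatic ring of carbon only), on a sulfur) in which 1-phenyl-1H-tetrazol-5-yl leaves a sulfur and a group with one five-membered non-aromatic ring with 2 hetero atoms enters.

Among the compounds with values here, two measured steps bear on this. The closer one (a 1.1-fold lower number from compound 2 to compound 3 (0.04 log units; within the scatter)) put 1-phenyl-1H-tetrazol-5-yl in place of pyridin-2-yl on that same sulfur, and the other (a 1.4-fold higher number from compound 1 to compound 2 (0.16 log units; within the scatter)) put (pyridin-2-yl)sulfanyl in place of 4-methylpiperazin-1-yl on an aromatic carbon. Within the data shown here, both stay within the scatter, so no step beyond the scatter is expected in this assay here, in either direction, although no measured compound carries the entering ring. The expected change is small (a 1.0-fold lower number from compound 3 to compound 4 (0.02 log units; within the scatter)) and remains an estimate. For compound 4 the expected value is 38000 nM with an estimated range from 18000 nM to 75000 nM as its limits.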

Compound 4, half-maximal inhibitory concentration: 44900 nM
Estimate against measurement, compound 4: 1.2-fold (0.07 log units) below; the range from low to high includes it.
By their numbers in this assay, from the lowest: compounds 1, 3, 2 and 4 (each within the scatter of the next).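

In this assay, the sulfur now carries a non-aromatic ring, yet this group of 5 heavy atoms cannot be told apart from the 1-phenyl-1H-tetrazol-5-yl group of 11 heavy atoms (a 1.1-fold higher number from compound 3 to compound 4 (0.06 log units; within the scatter)) or from the pyridin-2-yl group (a 1.0-fold higher number from compound 2 to compound 4 (0.02 log units; within the scatter)), so across these three groups neither the size of the group nor the aromatic character of its ring goes with any readable difference. The new sulfur-linked group also stays within the scatter of the 4-methylpiperazin-1-yl group on the aromatic carbon (a 1.5-fold higher number from compound 1 to compound 4 (0.17 log units; within the scatter)), which leaves all of the direct comparisons to compound 4 unresolved in this assay. No measurement at hand explains this lack of separation.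

What the compounds shown leave open is whether any group at this place can produce a step beyond the scatter at all, as each of these exchanges stays within it. A carboxylic acid, a primary amine or a longer alkyl chain on this sulfur would test that question, and such a result would show whether this position matters for the number in this assay.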